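This account rests on a few compounds, and the source may have more. Where it says the series, first, only, none or still open, it means among the compounds named here.

Compound 1 `C=CCCCn1c(Cc2cc(OC)c(OC)c(OC)c2)nc2c(N)nc(F)nc21` gives 44700 nM in a functional assay on MCF7 cells (Homo sapiens) for antiproliferative activity (a lower number here means a stronger inhibitor, a higher number a weaker inhibitor), the highest of the three numbers, although its gaps to compound 2 and compound 3 both lie within the scatter. Compound 2 `COc1cc(Cc2nc3c(N)ncnc3n2CC2CCCCC2)cc(OC)c1OC` gives 39800 nM in this assay, and compound 3 `COc1cc(Cc2nc3c(N)ncnc3n2CCOC(C)C)cc(OC)c1OC` gives 38900 nM. Their core differs slightly from that of compound 1, but the step of a 1.0-fold lower number from compound 2 to compound 3 (0.01 log units; within the scatter) swaps one side chain for another at the same place and changes nothing beyond the scatter. Compound 4 `CC[C@H](C)Cn1c(Cc2cc(OC)c(OC)c(OC)c2)nc2c(N)nc(F)nc21` differs from compound 1 by sec-butyl in place of but-3-en-1-yl on a saturated chain carbon bound to an aromatic nitrogen. Among the compounds with values here, the only measured step that bears on this change is that flat swap, so no movement beyond the scatter is expected here. Compound 4 is therefore estimated at 44000 nM, with a range from 20000 nM to 95000 nM. The expected step is a 1.0-fold lower number from compound 1 to compound 4 (0.01 log units; within the scatter).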

Compound 4, half-maximal inhibitory concentration: 43700 nM
Compound 4: middle estimate off by 1.0-fold (0.00 log units), on the high side; the range from low to high includes it.
By their numbers in this assay, from the lowest: compounds 3, 2, 4 and 1 (each within the scatter of the next).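

In this assay the swap of but-3-en-1-yl for sec-butyl gives a 1.0-fold lower number from compound 1 to compound 4 (0.01 log units; within the scatter) and extends the flat picture to the core of compound 1. At this place on the chain, removing the double bond and adding a defined stereocentre moves nothing beyond the scatter. Nothing available explains this flatness.

On these data alone, whether an amine or a carboxylic acid on this chain would shift the number remains open. So does the effect of a much longer chain.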